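Shifting the Chlorine on a Chlorophenyl Group

A few compounds are considered here, and "the series" means these few. Any claim that something is new, unique, unknown or untested is made for them only; others in the source may bear on it.

In a functional assay on SMMC-7721 cells (Homo sapiens) for cytotoxicity, read by MTT assay, with a stated time of 72 h (a higher number here means a weaker inhibitor, a lower number a stronger inhibitor), compound 1 `O=C(CCl)Nc1ccc(C(=O)/C=C/c2ccc(Cl)cc2)cc1` gives 8160 nM, compound 2 `O=C(CCl)Nc1ccc(C(=O)/C=C/c2ccc(Br)cc2)cc1` gives 13300 nM and compound 3 `O=C(CCl)Nc1ccc(C(=O)/C=C/c2ccccc2Cl)cc1` gives 11100 nM, so compound 3 stands within the scatter of both others. Compound 4 `O=C(CCl)Nc1ccc(C(=O)/C=C/c2cccc(Cl)c2)cc1` differs from compound 3 in one place: 3-chlorophenyl in place of 2-chlorophenyl on a double-bonded chain carbon bound to a double-bonded chain carbon. Here, 3-chlorophenyl takes the place of 2-chlorophenyl on a double-bonded chain carbon bound to a double-bonded chain carbon. The most similar measured change is a 1.4-fold higher number from compound 1 to compound 3 (0.13 log units; within the scatter), where 2-chlorophenyl replaces 4-chlorophenyl, and it lies within the scatter. So do a 1.6-fold higher number from compound 1 to compound 2 (0.21 log units; within the scatter) and a 1.2-fold lower number from compound 2 to compound 3 (0.08 log units; within the scatter). No step beyond the scatter is therefore expected in this assay, and the expected change is a 1.1-fold lower number from compound 3 to compound 4 (0.05 log units; within the scatter). For compound 4, the estimate is 10000 nM, with an expected range of 5500 nM to 18000 nM.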

Compound 4, half-maximal inhibitory concentration: 7760 nM
For compound 4 the middle estimate is 1.3-fold (0.11 log units) above the measured one; low and high end bracket the measured number.
By their numbers in this assay, from the lowest: compounds 4, 1, 3 and 2 (each within the scatter of the next).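

With compound 4, the 2-chlorophenyl, 3-chlorophenyl and 4-chlorophenyl versions can all be compared, and in this assay moving the chlorine stays within the scatter: a 1.4-fold lower number from compound 3 to compound 4 (0.16 log units; within the scatter) and a 1.1-fold lower number from compound 1 to compound 4 (0.02 log units; within the scatter) are both small. Replacing 4-bromophenyl with 3-chlorophenyl also stays within the scatter, giving a 1.7-fold lower number from compound 2 to compound 4 (0.23 log units; within the scatter) at this same place. Nothing measured here explains these small differences.

Every change shown only moves the chlorine or swaps it for bromine. From the compounds shown here alone, whether an amine or a carboxylic acid on that phenyl ring would give a step beyond the scatter remains open.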